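A few compounds are considered here, and "the series" means these few. Any claim that something is new, unique, unknown or untested is made for them only; others in the source may bear on it.

Measured so far:
compound 1 `CN1CCN(c2ccc(OCc3ccccc3)c(NCc3ccco3)c2)CC1`: 402 nM
compound 2 `CN1CCN(c2ccc(OCc3ccccc3)c(NCc3ccccc3)c2)CC1`: 928 nM

In an assay on HEK293 cells for displacement of a labelled ligand from 5-hydroxytryptamine receptor 6 (Homo sapiens) (a lower number here means a stronger inhibitor, a higher number a weaker inhibitor), compound 2 gives 928 nM, the higher of the two numbers recorded so far; compound 1 gives 402 nM. Within the data shown here, the only measured step, a 2.3-fold higher number from compound 1 to compound 2 (0.36 log units; beyond the scatter), sits on the saturated chain carbon bound to a nitrogen on an aromatic ring, the amine side of the shared core.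

Compound 3 `COc1ccc(N2CCN(C)CC2)cc1NCc1ccccc1` keeps that nitrogen side of compound 2 unchanged and alters the oxygen side: hydrogen in place of phenyl on a saturated chain carbon bound to an oxygen on an aromatic ring, read one bond further out as benzyloxy to methoxy. Among the measured compounds shown here, no measured step touches this position. For the measured compounds named here, the single step recorded concerns the other substituent, so it does not bear on the present change, and the benzyl group on the oxygen is present in both measured compounds, so its own contribution is not separated out by the data. The direction therefore cannot be read from the series. Expected for compound 3 is a modest step, a 1.6-fold higher number from compound 2 to compound 3 (0.21 log units; within the scatter), more likely toward a higher number than a lower one. Going by the values given here, compound 3 is estimated at 1500 nM, range 400 nM to 6000 nM, kept wide because no step informs it.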

Compound 3, inhibition constant: 409 nM
Compound 3: middle estimate off by 3.7-fold (0.56 log units), on the high side; measured number inside the range.
By their numbers in this assay, from the lowest: compounds 1 and 3 (each within the scatter of the next); then compound 2.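

In this assay, the oxygen side of the shared core now has its first measured step: benzyloxy to methoxy, hydrogen in place of phenyl on a saturated chain carbon bound to an oxygen on an aromatic ring, gives a 2.3-fold lower number from compound 2 to compound 3 (0.36 log units; beyond the scatter). The earlier compounds shown here carried benzyloxy throughout, so they could not show that this position affects the number, or that with the nitrogen side of compound 2 held fixed the phenyl can go without the number rising. No measurement available here accounts for the step.

From the compounds shown here alone, this direction rests on a single pair, and whether it carries over to the furan-2-yl group on the nitrogen side of compound 1 remains open. Also open, going by these compounds, is how the number responds along the oxygen substituent between and beyond these two groups, for example with a hydroxyl, an ethoxy group or a longer chain ending in a cyclohexyl ring in place of methoxy or benzyloxy.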